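Swapping oxy for amino in a hydroxyethyl carbonyl group

The source may hold more compounds than are shown below. What is called first, only, known or untested is meant among the compounds shown, and "the series" means these compounds.

Measured so far in a functional assay on SW-620 cells (Homo sapiens) for antiproliferative activity, read by sulforhodamine B assay, with a stated time of 48 h (a higher number here means a weaker inhibitor, a lower number a stronger inhibitor), with these values:
- compound 1 `C/C=C(\C)C(=O)O[C@H]1C=CC(=O)O[C@H]1CCC(=O)[C@H](C)O` gives 18000 nM here
- compound 2 `C/C=C(\C)C(=O)O[C@H]1C=CC(=O)O[C@H]1COC(=O)[C@H](C)O` gives 11000 nM here

Within the data shown here, compound 2 cannot be told apart from compound 1, the only other measured compound, since the data show a 1.6-fold lower number from compound 1 to compound 2 (0.21 log units; within the scatter) between them. Compound 3 `C/C=C(\C)C(=O)O[C@H]1C=CC(=O)O[C@H]1CNC(=O)[C@H](C)O` carries ((1-hydroxyethyl)carbonyl)amino in place of ((1-hydroxyethyl)carbonyl)oxy on a saturated chain carbon bound to a saturated ring carbon, counted as ((1-hydroxyethyl)carbonyl)amino in place of ((1-hydroxyethyl)carbonyl)oxy on a saturated chain carbon bound to a saturated ring carbon in full. Among the measured compounds shown here, the one measured step, at this same place, stayed within the scatter, so no step beyond the scatter is expected in this assay here. The estimate means a 1.2-fold higher number from compound 2 to compound 3 (0.07 log units; within the scatter) as the expected step. Compound 3 is expected near 13000 nM with an estimated range of 6000 nM to 30000 nM for repeated measurements.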

Compound 3, half-maximal inhibitory concentration: 25000 nM
Compound 3: the middle estimate sits 1.9-fold (0.28 log units) below what was measured, within the range that was stated.
By their numbers in this assay, from the lowest: compounds 2, 1 and 3 (each within the scatter of the next, the first and the last beyond it).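

Among these compounds, at the place on a saturated chain carbon bound to a saturated ring carbon, ((1-hydroxyethyl)carbonyl)amino in place of ((1-hydroxyethyl)carbonyl)oxy gives the first step beyond the scatter in this assay, though a modest one (a 2.3-fold higher number from compound 2 to compound 3 (0.36 log units; beyond the scatter)). Against ((1-hydroxyethyl)carbonyl)methyl, the same group stays within the scatter (a 1.4-fold higher number from compound 1 to compound 3 (0.14 log units; within the scatter)), so the series separates only at its two ends. Nothing measured here gives a reason for this difference.

On these data alone, whether a longer chain or a carboxylic acid at this place would shift the number further remains open, as does whether the hydroxyl of the 1-hydroxyethyl group contributes at all.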